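Chloro for hydrogen on two cores: growth inhibition notes

The compounds below may be only part of what the source reports. "The series", "measured", "known", "first", "only" and "open" are said of these compounds alone.

Compound 1 `Cc1ccc2nc(/N=C3\C(=O)N(CN4CCCCC4)c4ccccc43)sc2c1` and compound 3 `Cc1ccc2nc(/N=C3\C(=O)N(CN4CCCCC4)c4cccc(Cl)c43)sc2c1` share one core; compound 2 `CN(C)CN1C(=O)C(=O)c2ccccc21` and compound 4 `CN(C)CN1C(=O)C(=O)c2c(Cl)cccc21` share another, and the difference between the two cores is not broken down here. In an ADME assay on MCF-10A cells (Homo sapiens) for cytotoxicity, read by sulforhodamine B assay, with a stated time of 48 h (on this read-out lower numbers stand for stronger inhibition of growth and higher numbers for weaker inhibition of growth), compound 1 gives 38900 nM and compound 3 gives 30200 nM; the step of a 1.3-fold lower number from compound 1 to compound 3 (0.11 log units; within the scatter) comes from chloro in place of hydrogen on an aromatic carbon. In this assay compound 2 gives 150000 nM, the highest number among the three measured compounds. Compound 4 carries the same change, (chloro in place of hydrogen on an aromatic carbon), at the same kind of place on the second core. Because the earlier step of a 1.3-fold lower number from compound 1 to compound 3 (0.11 log units; within the scatter) stayed within the scatter, the estimated step to compound 4 in this assay is a 1.3-fold lower number from compound 2 to compound 4 (0.10 log units; within the scatter), resting on that single precedent alone. The estimate for compound 4 is 120000 nM, expected between 45000 nM and 320000 nM.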

Compound 4, concentration for 50% growth inhibition: 82300 nM
Estimate against measurement, compound 4: 1.5-fold (0.16 log units) above, within the range that was stated.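

In this assay, chloro in place of hydrogen on an aromatic carbon gives a 1.8-fold lower number from compound 2 to compound 4 (0.26 log units; within the scatter). Among these compounds, the two steps on the two cores do not differ: the same change on two cores in this assay, a 1.3-fold lower number (0.11 log units; within the scatter) from compound 1 to compound 3 and a 1.8-fold lower number (0.26 log units; within the scatter) from compound 2 to compound 4, 1.4-fold (0.15 log units) apart, within the scatter of two such steps Both steps are small, so this shows only that the change carried across these two cores without a step beyond the scatter; it does not show that chloro truly lowers the number on either core, and two cores set no rule for the series.

Going by these compounds, what a methoxy group, an amine or a carboxylic acid would do at the same aromatic carbon stays open. So does how chloro reads on any core other than those of compound 1 and compound 2.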